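Nitrophenyl alkyne series: shifting the nitro group

The source may hold more compounds than are shown below. What is called first, only, known or untested is meant among the compounds shown, and "the series" means these compounds.

Three analogues on one shared core have been measured in an assay for inhibition of Fatty-acid amide hydrolase 1 (Rattus norvegicus); a lower number here means a stronger inhibitor, a higher number a weaker inhibitor. Compound 1 `O=C(CCCCC#Cc1ccc(Cl)cc1)c1ncc(-c2ccccn2)o1` gives 20 nM. Compound 2 `O=C(CCCCC#Cc1cccc(Cl)c1Cl)c1ncc(-c2ccccn2)o1` gives 5 nM, and compound 3 `O=C(CCCCC#Cc1cccc([N+](=O)[O-])c1)c1ncc(-c2ccccn2)o1` gives 4.8 nM. Among the compounds with values here, compound 3 has the lowest number of the three, but its gap to compound 2 is within the scatter; only the step of a 4.2-fold lower number from compound 1 to compound 3 (0.62 log units; beyond the scatter) lies beyond it. Compound 4 `O=C(CCCCC#Cc1ccc([N+](=O)[O-])cc1)c1ncc(-c2ccccn2)o1` is the next member; it differs from compound 3 by 4-nitrophenyl in place of 3-nitrophenyl on a triple-bonded carbon. Within the data shown here, no measured step moves a nitro group alone. The two steps that start from a 4-chlorophenyl carrier, a 4.0-fold lower number from compound 1 to compound 2 (0.60 log units; beyond the scatter) and a 4.2-fold lower number from compound 1 to compound 3 (0.62 log units; beyond the scatter), are both modest and both leave compound 1 as the weaker side. Compound 4 carries 4-nitrophenyl as compound 1 carries 4-chlorophenyl, so compound 4 is expected to show a modest rise in the number, a 2.1-fold higher number from compound 3 to compound 4 (0.32 log units; beyond the scatter), possibly no larger than the scatter. Compound 4 is therefore estimated at 10 nM, with a range from 4 nM to 30 nM.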

Compound 4, inhibition constant: 31 nM
For compound 4 the middle estimate is 3.1-fold (0.49 log units) below the measured one; measured number above the stated range.
By their numbers in this assay, from the lowest: compounds 3 and 2 (each within the scatter of the next); then compounds 1 and 4 (each within the scatter of the next).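

Moving the nitro group alone is now a measured change at the triple-bonded carbon in this assay: the step of a 6.5-fold higher number from compound 3 to compound 4 (0.81 log units; beyond the scatter) comes with no change in the atoms, so the place of the nitro group on the phenyl ring matters here. The step of a 6.2-fold higher number from compound 2 to compound 4 (0.79 log units; beyond the scatter) also leaves 4-nitrophenyl on the weaker side against 2,3-dichlorophenyl. Nitro in place of chloro gives a 1.6-fold higher number from compound 1 to compound 4 (0.19 log units; within the scatter) and so does not separate 4-nitrophenyl from 4-chlorophenyl, which suggests that, among these four compounds alone, the placement of the group counts for more than the choice between these two groups, with no compound going against this.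

Nothing available here explains the effect of moving the nitro group. Going by these compounds, whether 2-nitrophenyl, 3-chlorophenyl or a 3-aminophenyl group on the same triple-bonded carbon would follow compound 3 or compound 4 remains open.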